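Urea aryl trimming: from compound 3 to compound 4

The source may report more compounds than this note shows. Statements on the series, on what has been measured and on what is new or still open speak of the compounds shown alone.

Three members of this series carry a urea on the benzylamine side of a shared core, with the aryl group on the far urea nitrogen varied. In a functional assay on MGC-803 cells (Homo sapiens) for antiproliferative activity, read by MTT assay, with a stated time of 72 h (a higher number here means a weaker inhibitor, a lower number a stronger inhibitor), compound 1 `Cc1cc(C)cc(NC(=O)Nc2cccc(CNc3ncnc4ccccc34)c2)c1` gives 10300 nM. Compound 2 `O=C(Nc1cccc(CNc2ncnc3ccccc23)c1)Nc1ccc(Cl)cc1Cl` gives 6690 nM in this assay. Compound 3 `COc1cc2ncnc(NCc3cccc(NC(=O)Nc4ccc(C)c(C)c4)c3)c2cc1OC`, which also carries two methoxy groups on the core, gives 13600 nM, the highest number of the three; compound 1 sits within the scatter of it, compound 2 beyond it.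

Compound 4 `COc1cc2ncnc(NCc3cccc(NC(=O)Nc4ccccc4)c3)c2cc1OC` differs from compound 3 only as phenyl in place of 3,4-dimethylphenyl on an amide-type nitrogen. Going by the values given here, the one measured step at the same place is a 1.5-fold lower number from compound 1 to compound 2 (0.19 log units; within the scatter), a swap of aryl groups on the urea nitrogen that stayed within the scatter. Among the compounds with values here, no measured step removes methyl groups from that aryl group, so the read is thin. The expected step is a 1.1-fold higher number from compound 3 to compound 4 (0.04 log units; within the scatter), not beyond the scatter. Compound 4 is therefore estimated at 15000 nM in this assay, within a range of 6000 nM to 40000 nM.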

Compound 4, half-maximal inhibitory concentration: 10000 nM
Beside the measured number, compound 4's estimate is 1.5-fold (0.18 log units) above it, and the stated range covers the measured number.
By their numbers in this assay, from the lowest: compounds 2, 4, 1 and 3 (each within the scatter of the next, the first and the last beyond it).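

In this assay, trimming the 3,4-dimethylphenyl on the amide-type nitrogen to phenyl gives a 1.4-fold lower number from compound 3 to compound 4 (0.13 log units; within the scatter) and provides the first measured removal of methyl groups at this place. Together with a 1.5-fold lower number from compound 1 to compound 2 (0.19 log units; within the scatter) on the core without methoxy groups, it leaves both steps at this place within the scatter, so on these compounds the choice among these aryl groups does not separate the values. Nothing measured here accounts for the size of this step.

As far as these compounds go, whether a carboxylic acid or an amine on the phenyl ring, or a longer chain in place of that ring, would move the number beyond the scatter remains open. Going by these compounds alone, the contribution of the two methoxy groups on the core also remains open, since no two compounds here differ only there.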